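The source may report more compounds than this note shows. Statements on the series, on what has been measured and on what is new or still open speak of the compounds shown alone.

Measured in a functional assay on HEL cells (Homo sapiens); a lower number here means that less compound is tolerated, a higher number that more compound is tolerated:

compound 1 `CCCCCCCc1cc2cn(COCCO)c(=O)nc2o1` gives 140000 nM
compound 2 `O=c1nc2occc2cn1COCCO` gives > 200000 nM, which is a limit
compound 3 `CCCCCC#Cc1cc2cn(COCCO)c(=O)nc2o1` gives > 50000 nM, which is a limit

Among the compounds with values here, compound 1 holds the only true number in this small set, since the other two values are limits, so it offers a single firm reference point. Compound 4 `CCCCCCCCc1cc2cn(COCCO)c(=O)nc2o1` has not yet been measured. It departs from compound 1 by one small change at the far end of the heptyl chain: methyl in place of hydrogen on a saturated chain carbon, seven bonds along the chain from an aromatic carbon. In words, this is methyl in place of hydrogen on a saturated chain carbon, seven bonds along the chain from an aromatic carbon.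

Within the data shown here, two measured steps touch that chain. Replacing the whole heptyl group with hydrogen gives an at least 1.4-fold higher number from compound 1 to compound 2 (0.15 log units; that floor lies within the scatter). Replacing heptyl with hept-1-yn-1-yl gives a step that the limit leaves unreadable from compound 1 to compound 3. Neither step shows a change beyond the scatter, and neither tests chain length directly, so the evidence is thin. No step beyond the scatter is therefore expected in this assay, with at most a slight drift towards a lower number. The expected change is a 1.2-fold lower number from compound 1 to compound 4 (0.07 log units; within the scatter). For compound 4 the estimated value is 120000 nM, with an expected range of 60000 nM to 200000 nM.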

Compound 4, half-maximal cytotoxic concentration: > 200000 nM
Compound 4: a limit, no number; the forecaster's own chance of this, stated with the estimate: 25%; at least 1.6-fold (0.22 log units) between middle value and limit.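

In this assay, within the data shown here, the methyl at the far end of the chain gives an at least 1.4-fold higher number from compound 1 to compound 4 (0.15 log units; that floor lies within the scatter), so this single added carbon shows no lower number and no step that can be placed beyond the scatter. Unlike the earlier changes, which removed the heptyl group or replaced it with hept-1-yn-1-yl, this one alters only the far end of the saturated chain and leaves the rest of compound 1 as it stands. The value of compound 4 is a limit, so the size of the step stays unknown and only its floor can be read: the limit of > 200000 nM in this assay, at which 2 of the 4 values shown sit.

Among these compounds, compound 1 remains the only compound with a true number, and the steps that involve compound 3 cannot be read, so no trend with chain length can be drawn from these compounds. As far as these compounds go, it remains open whether a longer chain such as decyl, a shorter one such as propyl, or a chain carrying an amine or a carboxylic acid would shift the number in this assay by more than the scatter.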